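The source may report more compounds than this note shows. Statements on the series, on what has been measured and on what is new or still open speak of the compounds shown alone.

Compound 1 `N=C(N)Nc1cccc(C(=O)NCC(=O)N[C@@H](CC(=O)O)C(=O)NCc2ccccc2)c1` gives 31 nM in an assay on a protein complex for binding affinity to integrin alpha-5/beta-1 (Homo sapiens), read by ELISA, with a stated time of 1 h; on this read-out lower numbers stand for stronger inhibition and higher numbers for weaker inhibition. Compound 2 `N=C(N)Nc1cccc(C(=O)NCC(=O)N[C@@H](CC(=O)O)C(=O)NC(c2ccccc2)c2ccccc2)c1` gives 22 nM in this assay, and compound 3 `N=C(N)Nc1cccc(C(=O)NCC(=O)N[C@@H](CC(=O)O)C(=O)Nc2cccc3ccccc23)c1` gives 22 nM in this assay. On these numbers compound 3 stands level with compound 2 at the digits shown, and its gap to compound 1 lies within the scatter, so the three measured compounds are not separated beyond it.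

Compound 4 `C[C@H](NC(=O)[C@H](CC(=O)O)NC(=O)CNC(=O)c1cccc(NC(=N)N)c1)c1ccccc1` differs from compound 3 in one place: 1-phenylethyl in place of naphthalen-1-yl on an amide-type nitrogen. Among the measured compounds shown here, two measured steps bear on this change. The step of a 1.4-fold lower number from compound 1 to compound 3 (0.15 log units; within the scatter) shows that exchanging benzyl for naphthalen-1-yl on that amide-type nitrogen leaves the number within the scatter. The step of a 1.4-fold lower number from compound 1 to compound 2 (0.15 log units; within the scatter) shows that placing phenyl on the saturated chain carbon bound to the amide-type nitrogen and an aromatic carbon likewise stays within the scatter. The move to 1-phenylethyl, a single six-membered aromatic ring of carbon only with one defined stereocentre, is of the same kind as these, so no step beyond the scatter is expected in this assay. Compound 4 is therefore estimated at 25 nM, with a range from 10 nM to 65 nM, which means an expected step of a 1.1-fold higher number from compound 3 to compound 4 (0.06 log units; within the scatter).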

Compound 4, half-maximal inhibitory concentration: 20 nM
Compound 4: middle estimate off by 1.3-fold (0.10 log units), on the high side; low and high end bracket the measured number.
By their numbers in this assay, from the lowest: compounds 4, 2, 3 and 1 (each within the scatter of the next).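

In this assay the exchange of naphthalen-1-yl for 1-phenylethyl on the amide-type nitrogen gives a 1.1-fold lower number from compound 3 to compound 4 (0.04 log units; within the scatter), so going from two six-membered aromatic rings of carbon only to one, from 10 heavy atoms to 8, and to a group with one defined stereocentre does not carry the number beyond the scatter. Methyl in place of hydrogen on the saturated chain carbon bound to an amide-type nitrogen and an aromatic carbon gives a 1.6-fold lower number from compound 1 to compound 4 (0.19 log units; within the scatter), which stays within the scatter just as phenyl on that carbon did in a 1.4-fold lower number from compound 1 to compound 2 (0.15 log units; within the scatter). Hydrogen, methyl and phenyl on that carbon are therefore not separated in this assay, and nothing shown gives a reason for this.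

What the compounds shown leave open is whether a group carrying an amine or a carboxylic acid on this nitrogen, or a longer chain such as 2-phenylethyl, would move the number beyond the scatter. Also open, going by these compounds, is whether 1-phenylethyl with the opposite configuration at its stereocentre would stay within the scatter of compound 4.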